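From triazolylmethyl to thiazolylamino on a shared core

This account rests on a few compounds, and the source may have more. Where it says the series, first, only, none or still open, it means among the compounds named here.

In an ADME assay on microsomes from liver (Homo sapiens) for metabolic stability (a higher number here means that the compound lasts longer, a lower number that the compound disappears faster), compound 2 `CC(C)C(Cc1nnc[nH]1)c1ccc(-c2ccc3cccc(F)c3c2)[nH]c1=O` has a half-life of 0.307 h, and compound 1 `CC(C)C(c1ncco1)c1ccc(-c2ccc3cccc(F)c3c2)[nH]c1=O` has one of 0.178 h. These two values lie within the scatter of each other, so neither can be ranked above the other. Compound 3 `CCn1ncc2c(F)cc(-c3ccc(C(CC)(CC)c4nnc(C)[nH]4)c(=O)[nH]3)cc21` gives > 3 h. That value is a limit of the assay and not a number. Compound 3 also differs from compound 2 in more than one place, so it offers no direct guide here.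

Compound 4 `CC(C)C(Nc1nccs1)c1ccc(-c2ccc3cccc(F)c3c2)[nH]c1=O` has not yet been measured. It carries (1,3-thiazol-2-yl)amino in place of (4H-1,2,4-triazol-3-yl)methyl on the same saturated chain carbon: (1,3-thiazol-2-yl)amino in place of (4H-1,2,4-triazol-3-yl)methyl on a saturated chain carbon bound to an aromatic carbon and a saturated chain carbon.

Among the compounds with values here, one measured step bears on this change, since it altered the group at that same place: a 1.7-fold higher number from compound 1 to compound 2 (0.24 log units; within the scatter). With so small a precedent, no shift beyond the scatter is expected in this assay. The estimate is a 1.2-fold lower number from compound 2 to compound 4 (0.09 log units; within the scatter). For compound 4 the expected half-life is 0.25 h, with an estimated range from 0.1 h to 0.6 h.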

Compound 4, half-life: 0.17 h
Compound 4: middle estimate off by 1.5-fold (0.17 log units), on the high side; measured number inside the range.
By their numbers in this assay, from the lowest: compounds 4, 1 and 2 (each within the scatter of the next). At a limit, above all of these: compound 3.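

In this assay, compound 4 puts a third group on the same saturated chain carbon, and both new steps stay within the scatter: a 1.8-fold lower number from compound 2 to compound 4 (0.26 log units; within the scatter) and a 1.0-fold lower number from compound 1 to compound 4 (0.02 log units; within the scatter). Among compounds 1, 2 and 4, then, replacing either earlier group with (1,3-thiazol-2-yl)amino, which brings in sulfur, has no effect that can be told from the scatter. Nothing shown gives a reason for this result.

As far as these compounds go, whether any group on this carbon can move the half-life beyond the scatter stays open, for example a carboxylic acid or a simple amine. From the compounds shown here alone, compound 3 gives > 3 h, a limit of the assay and not a number, but it differs from these compounds in more than one place, so which of its differences matters also stays open.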